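Swapping the chlorotrifluoromethylphenyl pattern on a urea-linked series

A few compounds are considered here, and "the series" means these few. Any claim that something is new, unique, unknown or untested is made for them only; others in the source may bear on it.

Measured so far:
compound 1 `CC(NC(=O)C#Cc1ccc(NC(=O)Nc2cc(C(F)(F)F)ccc2Cl)cc1)c1ccccc1` — 23200 nM
compound 2 `CC(NC(=O)/C=C/c1ccc(NC(=O)Nc2ccc(Cl)c(C(F)(F)F)c2)cc1)c1ccccc1` — 21200 nM
compound 3 `CC(NC(=O)C#Cc1ccc(NC(=O)Nc2ccc(Cl)c(C(F)(F)F)c2)cc1)c1ccccc1` — 21400 nM

All three compounds were tested in a functional assay on KETR3 cells (Homo sapiens) for inhibition, read by MTT assay, with a stated time of 120 h; on this read-out higher numbers stand for weaker inhibition and lower numbers for stronger inhibition. Compound 1 gives 23200 nM in this assay, compound 2 gives 21200 nM, and compound 3 gives 21400 nM. The three numbers lie close together, and none of them can be called the strongest or the weakest.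

Compound 3 and compound 1 share a core and differ in one place: 2-chloro-5-(trifluoromethyl)phenyl in place of 4-chloro-3-(trifluoromethyl)phenyl on an amide-type nitrogen. The step of a 1.1-fold higher number from compound 3 to compound 1 (0.04 log units; within the scatter) shows that this exchange left the number essentially where it was.

Compound 2 and compound 3 carry the same substituted ring on the urea, but their cores differ; the difference between the two cores is not broken down here. Their values in this assay are as close to each other as the two compounds above.

Compound 4 `CC(NC(=O)/C=C/c1ccc(NC(=O)Nc2cc(C(F)(F)F)ccc2Cl)cc1)c1ccccc1` has not yet been measured. It differs from compound 2 in exactly the same way that compound 1 differs from compound 3: 2-chloro-5-(trifluoromethyl)phenyl in place of 4-chloro-3-(trifluoromethyl)phenyl on an amide-type nitrogen. The place is the same in both pairs, an amide-type nitrogen whose other neighbour is a carbonyl carbon, so this is the same change made on the other core.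

Because the earlier step of a 1.1-fold higher number from compound 3 to compound 1 (0.04 log units; within the scatter) was flat, compound 4 is expected to sit close to compound 2, with an estimated step of a 1.0-fold higher number from compound 2 to compound 4 (0.02 log units; within the scatter). Compound 4 is therefore estimated at 22000 nM in this assay. The range expected for compound 4 runs from 11000 nM to 44000 nM.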

Compound 4, half-maximal inhibitory concentration: 14300 nM
Beside the measured number, compound 4's estimate is 1.5-fold (0.19 log units) above it; measured number inside the range.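

On the core of compound 2, putting 2-chloro-5-(trifluoromethyl)phenyl in place of 4-chloro-3-(trifluoromethyl)phenyl on the amide-type nitrogen gives a 1.5-fold lower number from compound 2 to compound 4 (0.17 log units; within the scatter) in this assay, so this step cannot be told apart from the ordinary spread of repeated measurements. Set beside the same change on the other core, the two steps cannot be told apart either, and as far as this read-out can show, the exchange carries over from one core to the other without a detectable difference: the same change on two cores in this assay, a 1.1-fold higher number (0.04 log units; within the scatter) from compound 3 to compound 1 and a 1.5-fold lower number (0.17 log units; within the scatter) from compound 2 to compound 4, 1.6-fold (0.21 log units) apart, within the scatter of two such steps. Among these compounds, this does not show that the two ring patterns are equivalent in general, since the comparison rests on only two pairs of compounds, two cores and one cell assay, and steps within the scatter can only say that any real effect is too small to be resolved here.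

The compounds shown leave open what other groups on this ring would do, such as an amine or a carboxylic acid in place of the chlorine or the trifluoromethyl group. They also leave open whether the exchange would stay as quiet on a core with a longer chain joining the urea-bearing ring to the amide carbonyl.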